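The compounds below may be only part of what the source reports. "The series", "measured", "known", "first", "only" and "open" are said of these compounds alone.

Compound 1 `Cc1cc(C(=O)O)ccc1OCCCCOc1ccc(C(=O)C(C)C)c(O)c1C` and compound 3 `Cc1c(OCCCCOc2ccc(F)c(C(=O)O)c2)ccc(C(=O)C(C)C)c1O` share a pair of aromatic rings joined by the same linker and both carry an isopropylcarbonyl group; how their two cores differ is not broken down here. In an assay on HEK293 cells for positive allosteric modulation of metabotropic glutamate receptor 2 (Rattus norvegicus), read by thallium flux, with a stated time of 2.5 min (on this read-out lower numbers stand for an effect already at smaller amounts and higher numbers for an effect only at larger amounts of compound), compound 1 gives 234 nM, while compound 3 gives 171 nM, a gap that lies within the scatter. Compound 2 `CC(=O)c1ccc(OCCCCOc2ccc(C(=O)O)cc2C)c(C)c1O` is compound 1 with methyl in place of isopropyl on a carbonyl carbon, and in this assay compound 2 gives 50 nM, which is a 4.7-fold lower number from compound 1 to compound 2 (0.67 log units; beyond the scatter). Compound 4 `CC(=O)c1ccc(OCCCCOc2ccc(F)c(C(=O)O)c2)c(C)c1O`, not yet measured, is derived from compound 3 by methyl in place of isopropyl on a carbonyl carbon, the same change at the same kind of place. Because the step of a 4.7-fold lower number from compound 1 to compound 2 (0.67 log units; beyond the scatter) was seen once on the core of compound 1, a step of comparable size is expected when it is repeated on the core of compound 3, so that compound 4 is estimated to show a 3.8-fold lower number from compound 3 to compound 4 (0.58 log units; beyond the scatter) in this assay. Compound 4 is therefore expected to give about 45 nM, with a plausible range from 20 nM to 110 nM.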

Compound 4, half-maximal effective concentration: 259 nM
Beside the measured number, compound 4's estimate is 5.8-fold (0.76 log units) below it, outside the stated range (above it).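

Set on the second core, methyl in place of isopropyl on a carbonyl carbon gives a 1.5-fold higher number from compound 3 to compound 4 (0.18 log units; within the scatter) in this assay. The same change therefore does not carry over at the same size from one core to the other in this series: the same change on two cores in this assay, a 4.7-fold lower number (0.67 log units; beyond the scatter) from compound 1 to compound 2 and a 1.5-fold higher number (0.18 log units; within the scatter) from compound 3 to compound 4, 7.1-fold (0.85 log units) apart, beyond the scatter of two such steps. For the compounds shown here, this shows that the size of the step from isopropylcarbonyl to acetyl depends on the core that carries it, but with only two pairs it does not show which difference between the two cores matters, nor how the change would read on any further core.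

The compounds shown leave open how an intermediate group such as propanoyl or a larger one such as cyclopropylcarbonyl would read on the carbonyl carbon of either core. They also leave open whether the two steps would still differ with an amide in place of the carboxylic acid, or with a longer chain as the linker.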